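Bromo removal on the isatin-derived thiosemicarbazone series

The compounds below may be only part of what the source reports. "The series", "measured", "known", "first", "only" and "open" are said of these compounds alone.

Two bromo-bearing members of the shared core have been measured in a functional assay on MDA-MB-468 cells (Homo sapiens) for cytotoxicity, read by sulforhodamine B assay, with a stated time of 48 h; on this read-out higher numbers stand for weaker inhibition of growth and lower numbers for stronger inhibition of growth. Compound 1 `NC(=S)N/N=C1/C(=O)N(CN2CCN(c3ccnc4cc(C(F)(F)F)ccc34)CC2)c2cccc(Br)c21` gives 30400 nM, and compound 2 `NC(=S)N/N=C1/C(=O)N(CN2CCN(c3ccnc4cc(C(F)(F)F)ccc34)CC2)c2cc(Br)ccc21` gives 39600 nM. Compound 2 carries the higher of the two numbers, but its gap to compound 1 lies within the scatter, so no order between them can be stated. Compound 3 `NC(=S)N/N=C1/C(=O)N(CN2CCN(c3ccnc4cc(C(F)(F)F)ccc34)CC2)c2ccccc21` is the debrominated analogue: hydrogen in place of bromo on an aromatic carbon, the place being an aromatic carbon of a six-membered aromatic ring of carbon only, part of a fused system of two rings. Going by the values given here, no step between measured compounds is available to anchor this change; the expectation is a shift from compound 2 to compound 3 of a 1.1-fold higher number from compound 2 to compound 3 (0.06 log units; within the scatter), at most a modest loss of growth inhibition and possibly none beyond the scatter. Compound 3 is accordingly estimated at 45000 nM, with a range of 20000 nM to 100000 nM, pending measurement.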

Compound 3, concentration for 50% growth inhibition: 10300 nM
Compound 3: the middle estimate sits 4.4-fold (0.64 log units) above what was measured, and the stated range ends above it.
By their numbers in this assay, from the lowest: compound 3; then compounds 1 and 2 (each within the scatter of the next).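

In this assay bromo is no asset at either place on the aromatic ring: hydrogen in its stead gives a 3.8-fold lower number from compound 2 to compound 3 (0.58 log units; beyond the scatter) and a 3.0-fold lower number from compound 1 to compound 3 (0.47 log units; beyond the scatter). Among these three compounds, growth inhibition is therefore stronger without bromo, whichever of the two places it occupies. Nothing at hand accounts for this difference. Open, on these data alone, is whether the loss is specific to bromo or also comes with fluoro, methyl or methoxy at these places. The compounds shown also leave open whether an amine or a carboxylic acid there would match hydrogen.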